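The source may hold more compounds than are shown below. What is called first, only, known or untested is meant among the compounds shown, and "the series" means these compounds.

In an ADME assay on MT4 cells (Homo sapiens) for cytotoxicity, read by MTT assay, with a stated time of 5 days (a lower number here means that less compound is tolerated, a higher number that more compound is tolerated), compound 1 `Cc1cc(/C=C/C#N)cc(C)c1Oc1cc(NCCN(C)C)nc(Nc2ccc(C#N)cc2)n1` gives 3040 nM while compound 2 `COC(Nc1cc(Oc2c(C)cc(/C=C/C#N)cc2C)nc(Nc2ccc(C#N)cc2)n1)OC` gives 3470 nM and the two stand level, within the usual scatter of each other. With only these two numbers in hand, compound 2 has no real rank yet. Compound 3 `Cc1cc(/C=C/C#N)cc(C)c1Oc1cc(NCC2CCCO2)nc(Nc2ccc(C#N)cc2)n1` carries (oxolan-2-yl)methyl in place of dimethoxymethyl on a nitrogen on an aromatic ring. Among the compounds with values here, the one measured step at that nitrogen (a 1.1-fold higher number from compound 1 to compound 2 (0.06 log units; within the scatter)) put dimethoxymethyl in place of 2-(dimethylamino)ethyl and stayed within the scatter. A single step is thin evidence, but it shows two different groups there giving matching numbers, and nothing measured points either way for the new group. The expected change is therefore none beyond the scatter, in either direction (a 1.1-fold lower number from compound 2 to compound 3 (0.02 log units; within the scatter)). Compound 3 is estimated in this assay at 3300 nM with a range from 1500 nM to 8000 nM expected for repeat measurements.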

Compound 3, half-maximal cytotoxic concentration: > 268000 nM
Compound 3 was reported as a limit (the forecaster's own chance of this, stated with the estimate: 10%); middle value at least 81-fold (1.90 log units) away from the limit.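

In this assay, the group on the nitrogen on an aromatic ring can move the number a long way: (oxolan-2-yl)methyl in place of dimethoxymethyl gives an at least 77-fold higher number from compound 2 to compound 3 (1.88 log units; beyond the scatter), and oxolan-2-yl in place of (dimethylamino)methyl on the saturated chain carbon gives an at least 88-fold higher number from compound 1 to compound 3 (1.94 log units; beyond the scatter). The earlier step, a 1.1-fold higher number from compound 1 to compound 2 (0.06 log units; within the scatter), gave no sign of this, so two different groups giving matching numbers did not mean that this nitrogen tolerates any change without effect. Compound 3 is reported only as a limit, not a number, so the full size of both steps stays unknown: the limit of > 268000 nM in this assay, at which 1 of the 3 values shown sits.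

The three compounds do not show whether the five-membered non-aromatic ring as a whole or its oxygen goes with the change. As far as these compounds go, what a cyclopentylmethyl group, with carbon in place of that oxygen, or an open methoxyethyl chain would give remains open.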